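The source may hold more compounds than are shown below. What is called first, only, known or untested is meant among the compounds shown, and "the series" means these compounds.

Measured in a physicochemical assay for solubility, read by HPLC, in phosphate buffer, at pH 7.4; a lower number here means a less soluble compound, a higher number a more soluble compound:
- Compound 1 `COc1ccc(-c2ccnc(Nc3cccc(S(N)(=O)=O)c3)n2)cc1`: 38400 nM
- Compound 2 `COc1ccc(-c2ccnc(Nc3ccc(C(N)=O)cc3)n2)cc1`: < 600 nM, a limit and not a number
- Compound 3 `NS(=O)(=O)c1cccc(Nc2nccc(-c3ccccc3)n2)c1`: 3400 nM

Compound 3 holds the lower of the two actual numbers, well under compound 1. Compound 4 `COc1cccc(-c2ccnc(Nc3cccc(S(N)(=O)=O)c3)n2)c1` follows from compound 3 with methoxy in place of hydrogen on an aromatic carbon, meta to a large group: methoxy in place of hydrogen on an aromatic carbon. Within the data shown here, one measured step bears on this: an 11-fold lower number from compound 1 to compound 3 (1.05 log units; beyond the scatter), large, with hydrogen in place of methoxy. Read in reverse, with the methoxy of compound 4 at another place on the ring, that step suggests a rise of smaller size. The expected step is a 3.2-fold higher number from compound 3 to compound 4 (0.51 log units; beyond the scatter), towards a higher number and beyond the scatter. For compound 4 the estimate is 11000 nM, with an expected range of 3000 nM to 40000 nM.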

Compound 4, solubility: < 600 nM
Compound 4 ended at the assay's limit; the forecaster's own chance of this, stated with the estimate: 5%; middle value at least 18-fold (1.26 log units) from the limit.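

In this assay methoxy in place of hydrogen gives an at least 5.6-fold lower number from compound 3 to compound 4 (0.75 log units; beyond the scatter) at this place, while removing the methoxy of 4-methoxyphenyl gave an 11-fold lower number from compound 1 to compound 3 (1.05 log units; beyond the scatter) and so the direction of the step depends on where methoxy stands. With nothing else changed, 3-methoxyphenyl in place of 4-methoxyphenyl gives an at least 64-fold lower number from compound 1 to compound 4 (1.80 log units; beyond the scatter) in the same read-out. Compound 4 sits at a limit and not at a number: the limit of < 600 nM in this assay, at which 2 of the 4 values shown sit.

As far as these compounds go, the true size of both steps stays open. Also open, from the compounds shown here alone, is how an amine, a carboxylic acid or a longer chain in place of methoxy would read at this place.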